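Swapping Nitro for Ethyl on a Shared Fused Core

A few compounds are considered here, and "the series" means these few. Any claim that something is new, unique, unknown or untested is made for them only; others in the source may bear on it.

compound 1: `CCCc1ccc(N2C(=O)NC3(CSC4=C3C(=O)c3ncccc3C4=O)C2=O)cc1` — 450 nM
compound 2: `O=C1NC(=O)C2(CSC3=C2C(=O)c2ncccc2C3=O)N1` — 3120 nM
compound 3: `O=C1C2=C(C(=O)c3ncccc31)C1(CS2)NC(=O)N(c2ccc([N+](=O)[O-])cc2)C1=O` — 1030 nM

Of the compounds shown here, three on one core have been measured in a functional assay on XF498 cells (Homo sapiens) for antiproliferative activity, read by MTT assay, with a stated time of 96 h; on this read-out higher numbers stand for weaker inhibition and lower numbers for stronger inhibition. Compound 3 stands second highest of the three numbers. Its nearest neighbour is compound 1, with a 2.3-fold higher number from compound 1 to compound 3 (0.36 log units; beyond the scatter); its furthest is compound 2, with a 3.0-fold lower number from compound 2 to compound 3 (0.48 log units; beyond the scatter). The third step, a 6.9-fold higher number from compound 1 to compound 2 (0.84 log units; beyond the scatter), shows that removing the whole aryl group from the ring nitrogen costs the most.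

Compound 4 is `CCc1ccc(N2C(=O)NC3(CSC4=C3C(=O)c3ncccc3C4=O)C2=O)cc1`. It differs from compound 3 in one place: ethyl in place of nitro on an aromatic carbon.

Going by the values given here, the step that bears most directly on this change is the one from compound 1 to compound 3, where propyl gave way to nitro and the number rose modestly; compound 4 runs that change back, only to a chain one carbon shorter than in compound 1. The other two steps say the aryl group matters, but do not separate ethyl from propyl. Compound 4 is therefore expected to move back toward compound 1, a modest lowering of the number, as a 2.1-fold lower number from compound 3 to compound 4 (0.31 log units; beyond the scatter). For compound 4 the estimate is 500 nM, with a range from 250 nM to 1000 nM.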

Compound 4, half-maximal inhibitory concentration: 1200 nM
For compound 4 the middle estimate is 2.4-fold (0.38 log units) below the measured one; the whole stated range lies below it.
By their numbers in this assay, from the lowest: compound 1; then compounds 3 and 4 (each within the scatter of the next); then compound 2.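

In this assay, exchanging nitro for ethyl at this position gives a 1.2-fold higher number from compound 3 to compound 4 (0.07 log units; within the scatter), so on this ring carbon these two groups cannot be told apart, although they share neither atoms nor hydrogen-bond acceptors. Shortening the chain by one carbon gives a 2.7-fold higher number from compound 1 to compound 4 (0.43 log units; beyond the scatter) and so separates ethyl from propyl, which the earlier compounds could not do; compound 1 now stands apart from both the 4-ethylphenyl and the 4-nitrophenyl compounds, while 4-ethylphenyl in place of hydrogen on the ring nitrogen still gives a 2.6-fold lower number from compound 2 to compound 4 (0.41 log units; beyond the scatter) and thus keeps a gain over the bare nitrogen. Nothing among the data shown accounts for why propyl differs from ethyl here, or why ethyl and nitro read alike.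

With only ethyl and propyl as chains, the compounds shown cannot tell whether the number follows chain length or whether propyl is a single favourable case. From the compounds shown here alone, whether a longer chain such as butyl would lower the number further, and whether an amine or a carboxylic acid on this carbon would read like propyl or like ethyl and nitro, remains open.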